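This account rests on a few compounds, and the source may have more. Where it says the series, first, only, none or still open, it means among the compounds named here.

Measured compounds:
- Compound 1, `COc1ccc2c(c1)OC(N)=C(C#N)C2c1ccccc1`, in a functional assay on T47D cells (Homo sapiens) for activation (a lower number here means that less compound is needed, a higher number that more compound is needed for the effect), gives 360000000 nM.
- Compound 2, `COc1ccc2c(c1)OC(N)=C(C#N)C2c1cccc(Br)c1`, gives 52000000 nM in this assay.
- Compound 3, `CCNc1ccc2c(c1)OC(N)=C(C#N)C2c1cc(Br)c(OC)c(OC)c1`, gives 14000000 nM in this assay.

Among these three numbers compound 2 stands second highest: compound 3 sits below it by a gap beyond the scatter, and compound 1 sits above it by a gap that is also beyond the scatter. Among the measured compounds shown here, the only single-site step within the measured set is the one from compound 1 to compound 2, a 6.9-fold lower number from compound 1 to compound 2 (0.84 log units; beyond the scatter), and that step is the one that bears on the change now considered.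

Compound 4, `COc1cccc(C2C(C#N)=C(N)Oc3cc(OC)ccc32)c1`, is reached from compound 2 by methoxy in place of bromo on an aromatic carbon. The bromo that compound 2 carries at this position is thus replaced by a methoxy, while the rest of the molecule stays the same. Nothing measured shows a methoxy at exactly this position as a single change, so the expectation can only be framed around the bromo step. Putting in bromo in place of hydrogen gave a modest drop in this assay; removing it again in favour of methoxy is expected to give back part of that drop, so a modest step upward, a 2.9-fold higher number from compound 2 to compound 4 (0.46 log units; beyond the scatter), is expected. Compound 4 is therefore estimated at 150000000 nM, with a plausible range from 40000000 nM to 450000000 nM.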

Compound 4, half-maximal effective concentration: 52000000 nM
Beside the measured number, compound 4's estimate is 2.9-fold (0.46 log units) above it; the measured number falls inside the stated range.
By their numbers in this assay, from the lowest: compound 3; then compounds 2 and 4 (each within the scatter of the next); then compound 1.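

In this assay, replacing bromo with methoxy on this aromatic carbon gives no change at the digits printed from compound 2 to compound 4 (within the scatter), so this assay does not separate the two groups at this position, even though they differ in size and methoxy adds a hydrogen-bond acceptor by the count of the two structures. Compound 1 carries only hydrogen at this carbon, and putting methoxy there gives a 6.9-fold lower number from compound 1 to compound 4 (0.84 log units; beyond the scatter), a step that matches a 6.9-fold lower number from compound 1 to compound 2 (0.84 log units; beyond the scatter), so the lower number seen with bromo is not unique to bromo and appears with a second, quite different group. No measured evidence here accounts for why these two groups give matching numbers.

Two groups are too few to show whether any group at this carbon gives this same step or only some do, and an amine, a carboxylic acid or a longer chain such as ethoxy could test that. On these data alone, it also remains open whether methoxy would give the same step on another carbon of this ring, since compounds 1, 2 and 4 vary only this one place.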